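A few compounds are considered here, and "the series" means these few. Any claim that something is new, unique, unknown or untested is made for them only; others in the source may bear on it.

Measured in a functional assay on HOP-62 cells (Homo sapiens) for inhibition, read by sulforhodamine B assay; a higher number here means a weaker inhibitor of growth, a lower number a stronger inhibitor of growth:
- Compound 1 `Cc1ccc2[nH]c(-c3ccc(-c4ccc(-c5ccc(N(C)C)cc5)cc4)cc3)nc2c1`: 4230 nM
- Compound 2 `COc1ccc(-c2ccc(-c3ccc(-c4nc5cc(C)ccc5[nH]4)cc3)cc2)cc1OC`: 2120 nM
- Compound 3 `Cc1ccc2[nH]c(-c3ccc(-c4ccc(-c5ccccc5)cc4)cc3)nc2c1`: 39300 nM

Compound 3 has the highest number of the three and is the weakest growth inhibitor here. Compound 4 `Cc1ccc2[nH]c(-c3ccc(-c4ccc(-c5ccc(F)cc5)cc4)cc3)nc2c1` differs from it by fluoro in place of hydrogen on an aromatic carbon, para to a large group: fluoro in place of hydrogen on an aromatic carbon. Going by the values given here, two measured steps bear on this change, a 9.3-fold higher number from compound 1 to compound 3 (0.97 log units; beyond the scatter) and a 19-fold higher number from compound 2 to compound 3 (1.27 log units; beyond the scatter), and both show that compound 3, without those substituents, has the higher number. Compounds 1 and 2 themselves differ little: a 2.0-fold lower number from compound 1 to compound 2 (0.30 log units; within the scatter). Among the compounds with values here, no fluoro compound has been measured, so only a small shift toward a lower number is expected in this assay. The expected step is a 1.8-fold lower number from compound 3 to compound 4 (0.25 log units; within the scatter). For compound 4 the estimate is 22000 nM, with an expected range of 7000 nM to 60000 nM.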

Compound 4, concentration for 50% growth inhibition: 33500 nM
Compound 4: the middle estimate sits 1.5-fold (0.18 log units) below what was measured, within the range that was stated.
By their numbers in this assay, from the lowest: compounds 2 and 1 (each within the scatter of the next); then compounds 4 and 3 (each within the scatter of the next).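

In this assay, fluoro in place of hydrogen on this aromatic carbon, para to a large group, leaves the number essentially unchanged (a 1.2-fold lower number from compound 3 to compound 4 (0.07 log units; within the scatter)). Fluoro does not match the other substituents here, since replacing dimethylamino with it (a 7.9-fold higher number from compound 1 to compound 4 (0.90 log units; beyond the scatter)) and replacing 3,4-dimethoxyphenyl with 4-fluorophenyl (a 16-fold higher number from compound 2 to compound 4 (1.20 log units; beyond the scatter)) both give clearly weaker growth inhibition. So, among these compounds, a substituent at this position does not by itself lower the number, and nothing shown explains why. Going by these compounds, whether a single methoxy group or a carboxylic acid here would behave like fluoro or like dimethylamino remains open.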